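This account rests on a few compounds, and the source may have more. Where it says the series, first, only, none or still open, it means among the compounds named here.

Measured so far:
- compound 1 `CN1CCN(c2ccc(C3=NN(C(=O)c4ccc(C(F)(F)F)cc4)C(c4ccc(N(C)C)cc4)C3)cc2)CC1`: 84.1%
- compound 2 `CN1CCN(c2ccc(C3=NN(S(C)(=O)=O)C(c4ccc(N(C)C)cc4)C3)cc2)CC1`: -18.5%
- compound 3 `CN1CCN(c2ccc(C3=NN(S(=O)(=O)C4CC4)C(c4ccc(N(C)C)cc4)C3)cc2)CC1`: 4.7%

All three share one core and differ only in the group on the ring nitrogen. In a functional assay on HCC1806 cells (Homo sapiens) for inhibition, read by sulforhodamine B assay, tested at 10 uM (on this read-out lower numbers stand for less inhibition and higher numbers for more inhibition at the one concentration tested (going by the name of the read-out)), compound 3 stands second highest of the three. It sits above compound 2, the nearest number, by a number 23.2 percentage points higher from compound 2 to compound 3 (beyond the scatter), and far below compound 1 by a number 79.4 percentage points lower from compound 1 to compound 3 (beyond the scatter); the parallel drop a number 102.6 percentage points lower from compound 1 to compound 2 (beyond the scatter) shows that either sulfonyl loses almost all of the inhibition the carbonyl of compound 1 carries.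

Compound 4 `CN1CCN(c2ccc(C3=NN(S(=O)(=O)c4ccc(C#N)cc4)C(c4ccc(N(C)C)cc4)C3)cc2)CC1` is not yet measured. The change from compound 3 is 4-cyanophenyl in place of cyclopropyl on a sulfonyl sulfur. Among the compounds with values here, no measured step exchanges cyclopropyl for a six-membered aromatic ring on the sulfonyl sulfur, so the only guidance is indirect: enlarging the sulfonyl substituent from methyl to cyclopropyl gave the modest gain a number 23.2 percentage points higher from compound 2 to compound 3 (beyond the scatter), while the numbers of both sulfonyl compounds stay far below that of compound 1. A further modest rise, still well short of compound 1, is therefore expected. The step from compound 3 is estimated at a number 17.3 percentage points higher from compound 3 to compound 4 (beyond the scatter). For compound 4 the expected value is 22%, in the range -8% to 55%.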

Compound 4, a percentage reported as inhibition, at one concentration (the size of the read-out at that concentration, not a potency): 99.8%
The estimate for compound 4 lay 77.8 percentage points below the measured number; measured number outside the range, above it.
By their numbers in this assay, from the lowest: compound 2; then compound 3; then compound 1; then compound 4.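

In this assay, the sulfonyl link does not by itself remove the inhibition at this ring nitrogen: 4-cyanophenyl on the sulfonyl sulfur gives a number 95.1 percentage points higher from compound 3 to compound 4 (beyond the scatter) in place of cyclopropyl and a number 118.3 percentage points higher from compound 2 to compound 4 (beyond the scatter) in place of methyl, so the group on the sulfur decides the read-out in this set. Exchanging the (4-(trifluoromethyl)phenyl)carbonyl group for (4-cyanophenyl)sulfonyl gives a number 15.7 percentage points higher from compound 1 to compound 4 (beyond the scatter), so the low numbers of the methylsulfonyl and cyclopropylsulfonyl compounds do not extend to every sulfonyl group. No available evidence explains the size of these steps.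

The compounds shown leave open whether the gain requires the nitrile or only the six-membered aromatic ring, a distinction that plain phenyl on the sulfonyl sulfur would address. As far as these compounds go, how a ring carrying an amine or a carboxylic acid in place of the nitrile would read also remains open.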